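Cytotoxicity series: varying the benzyl arm toward compound 4

The compounds below may be only part of what the source reports. "The series", "measured", "known", "first", "only" and "open" are said of these compounds alone.

Compound 2 `O=c1ccoc2cc(OCc3cn(Cc4cccc(Br)c4)nn3)ccc12` gives in an ADME assay on L02 cells (Homo sapiens) for cytotoxicity, read by MTT assay, with a stated time of 48 h (a lower number here means a stronger inhibitor, a higher number a weaker inhibitor), only a limit of the assay, > 300000 nM. Compound 1 `Cc1cccc(Cn2cc(COc3ccc4c(=O)ccoc4c3)nn2)c1` likewise gives only a limit in this assay, > 300000 nM. Compound 3 `O=c1ccoc2cc(OCc3cn(Cc4ccccc4Cl)nn3)ccc12` also gives only a limit in this assay, > 300000 nM. The measured steps are a step that the two limits leave unreadable from compound 1 to compound 2, a step that the two limits leave unreadable from compound 1 to compound 3 and a step that the two limits leave unreadable from compound 2 to compound 3, none of them readable in size because of the limit of > 300000 nM in this assay, at which 3 of the 3 values shown sit. Compound 4 `COc1ccc(Cn2cc(COc3ccc4c(=O)ccoc4c3)nn2)cc1` differs from compound 2 at the chain carbon bound to an aromatic nitrogen: 4-methoxyphenyl in place of 3-bromophenyl on a saturated chain carbon bound to an aromatic nitrogen. All three measured steps bear on this change, yet none supplies a size or a direction. For compound 4 no step beyond the scatter is expected in this assay, the expected step being a step that the limit leaves unreadable from compound 2 to compound 4. Compound 4 is estimated at 400000 nM, with a range from 200000 nM to 1000000 nM, most likely reported again only as a limit.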

Compound 4, half-maximal inhibitory concentration: > 300000 nM
Compound 4 ended at the assay's limit; the forecaster's own chance of this, stated with the estimate: 85%; the middle value does not contradict the limit.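

No new step can be read between compound 4 and compound 1, compound 2 or compound 3, since each gives only a limit: the limit of > 300000 nM in this assay, at which 4 of the 4 values shown sit. In this assay the compounds shown leave open whether any benzyl arm on the shared core gives a readable value.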